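Swapping the 3-methylphenyl group of compound 3

The source may report more compounds than this note shows. Statements on the series, on what has been measured and on what is new or still open speak of the compounds shown alone.

Compound 1 `COc1cc(-c2ccnc3cc(-c4c[nH]c5ccccc45)nn23)cc(OC)c1OC` gives 195 nM
Compound 2 `COc1cc(-c2ccnc3cc(-c4cn(C)c5ccccc45)nn23)cc(OC)c1OC` gives 399 nM
Compound 3 `COc1cc(-c2ccnc3cc(-c4cccc(C)c4)nn23)cc(OC)c1OC` gives 4230 nM

In a functional assay on HeLa cells (Homo sapiens) for inhibition, read by CCK-8 assay, with a stated time of 48 h (a lower number here means a stronger inhibitor, a higher number a weaker inhibitor), compound 3 has the highest number of the three and is the weakest inhibitor measured, with compound 2 nearest to it and compound 1 furthest away. The next compound to be read is compound 4 `COc1cc(-c2ccnc3cc(-c4ccc(C(C)=O)cc4)nn23)cc(OC)c1OC`, which has not yet been measured. The change is 4-acetylphenyl in place of 3-methylphenyl on an aromatic carbon and it sits on an aromatic carbon of a five-membered aromatic ring with 2 nitrogen, part of a fused or bridged system of two rings.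

Two measured steps act at this same place: a 22-fold higher number from compound 1 to compound 3 (1.34 log units; beyond the scatter) and an 11-fold higher number from compound 2 to compound 3 (1.03 log units; beyond the scatter) are both large. Each of them, however, exchanges an indolyl group for 3-methylphenyl, whereas compound 4 keeps a substituted phenyl ring. The modest step of a 2.0-fold higher number from compound 1 to compound 2 (0.31 log units; beyond the scatter) is made on an aromatic nitrogen and bears on this change only weakly. Within the data shown here, no measured pair compares two substituted phenyl groups, so the direction remains open. In this assay the expected result is a 1.2-fold higher number from compound 3 to compound 4 (0.07 log units; within the scatter) and no large shift is anticipated. Compound 4 is estimated at 5000 nM with an expected range of 1500 nM to 17000 nM in this assay.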

Compound 4, half-maximal inhibitory concentration: 1810 nM
Beside the measured number, compound 4's estimate is 2.8-fold (0.44 log units) above it; measured number inside the range.
By their numbers in this assay, from the lowest: compound 1; then compound 2; then compound 4; then compound 3.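

In this assay, among these compounds, a 2.3-fold lower number from compound 3 to compound 4 (0.37 log units; beyond the scatter); this is the first comparison of two substituted phenyl groups on this aromatic carbon, and it shows that the number at this place can move while a phenyl ring is kept, with 4-acetylphenyl the stronger of the pair. The indolyl groups remain ahead of 4-acetylphenyl, with a 4.5-fold higher number from compound 2 to compound 4 (0.66 log units; beyond the scatter) and a 9.3-fold higher number from compound 1 to compound 4 (0.97 log units; beyond the scatter), so compound 4 closes only part of the distance between compound 3 and the two indolyl compounds. No supporting measurement is available to explain these differences in number.

The change from 3-methylphenyl to 4-acetylphenyl alters both the substituent and its place on the phenyl ring, so the compounds shown leave open which of the two accounts for the step; a comparison of 4-methylphenyl with 3-acetylphenyl at this carbon would help to separate them. Also open, on these data alone, is whether the carbonyl itself matters, a question that a 4-(1-hydroxyethyl)phenyl, 4-aminophenyl or 4-carboxyphenyl group in place of 4-acetylphenyl could address.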